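A few compounds are considered here, and "the series" means these few. Any claim that something is new, unique, unknown or untested is made for them only; others in the source may bear on it.

Compound 1 `Cc1ccc(-n2nccn2)c(C(=O)N2C[C@@H]3CN(c4nc5ccccc5n4C)C[C@@H]3C2)c1` gives 1640 nM in a functional assay on HEK293 cells for antagonist activity at Orexin/Hypocretin receptor type 1 (Homo sapiens), read by FLIPR and calcium flux, with a stated time of 60 min; on this read-out lower numbers stand for stronger inhibition and higher numbers for weaker inhibition. Compound 2 `Cc1ccc(-n2nccn2)c(C(=O)N2C[C@@H]3CN(c4nc(C)c(C)c(C)n4)C[C@@H]3C2)c1` reaches only the limit of this assay, > 10000 nM, in this assay. The step of an at least 6.0-fold higher number from compound 1 to compound 2 (0.78 log units; beyond the scatter) therefore rests on that limit (the limit of > 10000 nM in this assay, at which 1 of the 2 values shown sits). Compound 3 `Cc1ccc(-n2nccn2)c(C(=O)N2C[C@@H]3CN(c4ncnc5ccccc45)C[C@@H]3C2)c1` differs from compound 2 by quinazolin-4-yl in place of 4,5,6-trimethylpyrimidin-2-yl on an amine nitrogen in a ring, bringing back a two-ring aromatic group, as in compound 1. Among the measured compounds shown here, only that one measured step bears on this change, and the loss seen in an at least 6.0-fold higher number from compound 1 to compound 2 (0.78 log units; beyond the scatter) is expected to reverse in this assay, at least in part. Compound 3 is thus expected at 2500 nM in this assay, between 600 nM and 10000 nM, a gain of an at least 4.0-fold lower number from compound 2 to compound 3 (0.60 log units; beyond the scatter).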

Compound 3, half-maximal inhibitory concentration: > 10000 nM
Compound 3: a limit, no number; the forecaster's own chance of this, stated with the estimate: 30%; at least 4.0-fold (0.60 log units) between middle value and limit.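

In this assay compound 3 sits at a limit, > 10000 nM, not a number, so a two-ring aromatic group on this amine nitrogen does not by itself restore the activity of compound 1. Quinazolin-4-yl thus falls short of 1-methyl-1H-benzimidazol-2-yl, with an at least 6.0-fold higher number from compound 1 to compound 3 (0.78 log units; beyond the scatter). The step from compound 2 to compound 3 cannot be read, and the series now gathers at one limit: the limit of > 10000 nM in this assay, at which 2 of the 3 values shown sit.

As far as these compounds go, it remains open which part of 1-methyl-1H-benzimidazol-2-yl matters, and whether a benzoxazol-2-yl or quinazolin-2-yl group here would give a readable number.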